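Tert-Butyl in Place of a Trifluoromethylphenyl Group

This account rests on a few compounds, and the source may have more. Where it says the series, first, only, none or still open, it means among the compounds named here.

Among the measured compounds shown here, compound 3 `CN1CCN(CCNCc2cn(-c3ccc(F)cc3F)nc2-c2ccc(C(F)(F)F)cc2)CC1` gives 20000 nM in an ADME assay on Huh-7 cells (Homo sapiens) for cytotoxicity (on this read-out lower numbers stand for higher toxicity in this test and higher numbers for lower toxicity in this test), the only plain number among the three values shown. Compound 1 `CN1CCN(CCNCc2cn(-c3ccc(F)cc3F)nc2Cc2ccccc2)CC1` sits at the limit of > 20000 nM in this assay. Compound 2 `COC(=O)c1ccc(-c2nn(-c3ccc(F)cc3F)cc2CNCCN2CCN(C)CC2)cc1` likewise sits at the limit of > 20000 nM in this assay. Compound 4 `CN1CCN(CCNCc2cn(-c3ccc(F)cc3F)nc2C(C)(C)C)CC1` differs from compound 3 by tert-butyl in place of 4-(trifluoromethyl)phenyl on an aromatic carbon. For the measured compounds named here, the steps that bear on it, a number no higher from compound 1 to compound 3 (the limit leaves the size open) and a number no higher from compound 2 to compound 3 (the limit leaves the size open), leave their size open due to the limit of > 20000 nM in this assay, at which 2 of the 3 values shown sit, and a step that the two limits leave unreadable from compound 1 to compound 2 is unreadable for the same reason. Going by the values given here, no step sets a direction, so compound 4 is expected to stay where compound 3 stands, with an expected step of no change at the digits printed from compound 3 to compound 4 (within the scatter). The estimate for compound 4 is 20000 nM, between 10000 nM and 40000 nM.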

Compound 4, half-maximal cytotoxic concentration: > 20000 nM
Compound 4: no number, only a limit; the forecaster's own chance of this, stated with the estimate: 60%; the middle value sits exactly at the limit.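

In this assay compound 4 gives > 20000 nM, which is a limit of the assay and not a number. Tert-butyl brings no ring to this aromatic carbon, unlike the groups before it, yet the change gives a number no lower from compound 3 to compound 4 (the limit leaves the size open). The steps to compound 4 from compound 1 and compound 2 cannot be read, and the size of every step here stays unknown due to the limit: the limit of > 20000 nM in this assay, at which 3 of the 4 values shown sit.

As far as these compounds go, what an amine or a carboxylic acid on this carbon would give remains open. So does whether any group here gives a number clearly lower than that of compound 3.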